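The compounds below may be only part of what the source reports. "The series", "measured", "known", "first", "only" and "open" are said of these compounds alone.

Working notes on the series in a functional assay on the whole organism with Rattus norvegicus as the target, in the maximal electroshock model; on this read-out higher numbers stand for an effect only at larger amounts of compound and lower numbers for an effect already at smaller amounts.

Compound 1 `CC(C)Nc1ncnc2c1ncn2Cc1ccccc1F` gives 5.8 mg/kg in this assay. Compound 2 `Fc1ccccc1Cn1cnc2c(NC3CCCC3)ncnc21` gives 8 mg/kg. Going by the values given here, the one measured step, cyclopentyl in place of isopropyl on a nitrogen on an aromatic ring, is a 1.4-fold higher number from compound 1 to compound 2 (0.14 log units; within the scatter). Among the compounds with values here, compound 2 thus shows the higher of the two numbers, but its only neighbour, compound 1, lies within the scatter of it, so no order between the two can be read.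

Compound 3 `CN(C)c1ncnc2c1ncn2Cc1ccccc1F` is not yet measured. It differs from compound 2 by dimethylamino in place of cyclopentylamino on an aromatic carbon. Within the data shown here, no measured step removes the hydrogen-bond donor or shortens the substituent at this place; the step from compound 1 to compound 2 only exchanged one alkyl group for another and stayed within the scatter. For compound 3 a step of a 1.5-fold higher number from compound 2 to compound 3 (0.18 log units; within the scatter) towards a higher number is therefore expected, with wide uncertainty. The estimate for compound 3 is 12 mg/kg, in the range 4 mg/kg to 35 mg/kg.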

Compound 3, dose for half-maximal effect: 8.8 mg/kg
Beside the measured number, compound 3's estimate is 1.4-fold (0.13 log units) above it; low and high end bracket the measured number.
By their numbers in this assay, from the lowest: compounds 1, 2 and 3 (each within the scatter of the next).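

Dimethylamino brings 0 hydrogen-bond donors, no ring and 3 heavy atoms where cyclopentylamino has 1 hydrogen-bond donor, a five-membered ring and 6 heavy atoms, and this exchange gives a 1.1-fold higher number from compound 2 to compound 3 (0.04 log units; within the scatter) in this assay; the exchange for isopropylamino gives a 1.5-fold higher number from compound 1 to compound 3 (0.18 log units; within the scatter). The earlier step only swapped one alkyl group for another on a nitrogen that kept its hydrogen, whereas these two show that, among the three compounds, the read-out does not separate a substituent with a hydrogen-bond donor at this aromatic carbon from one without. No measurement in hand bears on why these values lie so close.

Open, on these data alone, is whether this holds once the nitrogen itself is replaced, as with a methoxy group or a plain methyl group. As far as these compounds go, a larger ring amine such as morpholine and a longer chain such as n-hexylamino are equally open.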